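The source may hold more compounds than are shown below. What is called first, only, known or untested is meant among the compounds shown, and "the series" means these compounds.

Compound 1 `COc1cc(N2C(N)=C(C#N)C(c3cccc([N+](=O)[O-])c3)C3=C2CC(C)(C)CC3=O)cc(OC)c1OC` gives 20% in a functional assay on Ehrlich cells (Mus musculus) for cytotoxicity, tested at 25 ug/mL; a higher number here means a stronger effect of the compound at the concentration tested, a lower number a weaker effect. Compound 2 `COc1cc(N2C(N)=C(C#N)C(c3ccccc3Cl)C3=C2CC(C)(C)CC3=O)cc(OC)c1OC` gives 15%. Compound 3 `COc1cc(N2C(N)=C(C#N)C(c3ccc(C)cc3)C3=C2CC(C)(C)CC3=O)cc(OC)c1OC` gives 50%.

Among these three numbers, compound 2 carries the lowest value, although its gap to compound 1, a number 5 percentage points lower from compound 1 to compound 2 (within the scatter), is within the scatter, so the two cannot be told apart. Only compound 3 stands clearly apart: the step of a number 35 percentage points higher from compound 2 to compound 3 (beyond the scatter) is large, and the step of a number 30 percentage points higher from compound 1 to compound 3 (beyond the scatter) is modest.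

Compound 4 `COc1cc(N2C(N)=C(C#N)C(c3ccccc3)C3=C2CC(C)(C)CC3=O)cc(OC)c1OC` differs from compound 2 by a single change: hydrogen in place of chloro on an aromatic carbon.

Neither measured step removes a group from the phenyl ring outright; both swap one substituted phenyl for another. The swap from 3-nitrophenyl to 2-chlorophenyl, a number 5 percentage points lower from compound 1 to compound 2 (within the scatter), stayed within the scatter, while the swap to 4-methylphenyl, a number 35 percentage points higher from compound 2 to compound 3 (beyond the scatter), was large. The bare phenyl of compound 4 sits outside these comparisons, so the expectation must be cautious. The step in this assay is estimated at about a number 10 percentage points higher from compound 2 to compound 4 (within the scatter), a small expected rise that may well stay within the scatter.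

Compound 4 is therefore estimated at 25%, within a range of 10% to 45%.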

Compound 4, a percentage reported as activity, at one concentration (the size of the read-out at that concentration, not a potency): 6%
The estimate for compound 4 lay 19 percentage points above the measured number; the whole stated range lies above it.
By their numbers in this assay, from the lowest: compounds 4, 2 and 1 (each within the scatter of the next, the first and the last beyond it); then compound 3.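

With the bare phenyl of compound 4 in hand, each substituted ring in this assay can be compared with an unsubstituted one. Hydrogen in place of chloro gives a number 9 percentage points lower from compound 2 to compound 4 (within the scatter), so the 2-chlorophenyl of compound 2 cannot be told apart from plain phenyl, while hydrogen in place of nitro gives a number 14 percentage points lower from compound 1 to compound 4 (beyond the scatter) and hydrogen in place of methyl gives a number 44 percentage points lower from compound 3 to compound 4 (beyond the scatter), which means that these substituents do not all count alike and that the methyl-bearing ring of compound 3 stands furthest from the bare ring. Nothing measured alongside these numbers gives a reason for the differences between these steps.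

It stays open whether the high reading of compound 3 belongs to the methyl group itself or to where that group sits, since the compounds shown carry each substituent at one place on the ring only. On these data alone, how an ethyl group, a longer chain or an amine on this same ring would read in this assay is also open.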